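A lactam gives way to an anilino group on a shared core

The compounds below may be only part of what the source reports. "The series", "measured", "known", "first", "only" and "open" are said of these compounds alone.

Of the compounds shown here, three have been measured in a physicochemical assay for lipophilicity, using the shake flask method, in phosphate buffer, measured as octanol-water partition, with a stated time of 30 min, at pH 7.4; on this read-out higher numbers stand for higher lipophilicity and lower numbers for lower lipophilicity. Among the measured compounds shown here, compound 1 `Cc1nccn1-c1cnc(NCc2c(F)ccc3c2CCO3)c2cn[nH]c(=O)c12` gives 2.1, and compound 2 `CN(C)C(=O)c1cc(-c2cnc(NCc3c(F)ccc4c3CCO4)c3cn[nH]c(=O)c23)n(C)n1` gives 2.1; the single step between them, no change at the digits printed from compound 1 to compound 2 (within the scatter), does not touch the position altered here. Compound 3 `CC1(C)CC(=O)N(c2cnc(NCc3c(F)ccc4c3CCO4)n3cnnc23)C1` gives 2, the lowest of the three numbers, though its distances to compound 1 and compound 2 both lie within the scatter. Compound 4 `Fc1ccc2c(c1CNc1ncc(Nc3ccccc3)c3nncn13)CCO2` differs from compound 3 by anilino in place of 4,4-dimethyl-2-oxopyrrolidin-1-yl on an aromatic carbon. For the measured compounds named here, no measured step covers such an exchange, so the expectation rests on the structural change alone. Compound 4 is expected to sit higher in this assay, with an estimated step of a number 1.00 log units higher from compound 3 to compound 4 (beyond the scatter). Compound 4 is therefore estimated at 3, within a range from 2.3 to 3.7.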

Compound 4, distribution coefficient: 3.3
Compound 4: middle estimate off by 0.30 log units, on the low side; measured number inside the range.
By their numbers in this assay, from the lowest: compounds 3, 1 and 2 (each within the scatter of the next); then compound 4.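

In this assay, anilino in place of 4,4-dimethyl-2-oxopyrrolidin-1-yl on this aromatic carbon gives a number 1.30 log units higher from compound 3 to compound 4 (beyond the scatter). Among the compounds shown here, this shows that the read-out can respond to a change at this position, whereas the only earlier step, no change at the digits printed from compound 1 to compound 2 (within the scatter), was made at a position on another core and stayed within the scatter. Nothing available explains the size of this step. Still open, as far as these compounds go, is whether a cyclohexylamino or phenoxy group at this place would give a similar step. From the compounds shown here alone, it is also open whether anilino would do the same on the core of compound 1.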